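A few compounds are considered here, and "the series" means these few. Any claim that something is new, unique, unknown or untested is made for them only; others in the source may bear on it.

Compound 1 `O=C(N[C@H]1CCC[C@H](CO)C1)C1CCN(c2nc3cc(Cl)c(-c4ccc(F)cc4)cc3o2)CC1` is the reference point of this set. Within the data shown here, in an ADME assay on microsomes from liver (Homo sapiens) for metabolic stability (a lower number here means slower removal, a higher number faster removal of the compound), compound 1 gives 81.9 mL/min/kg, the highest of the three numbers known so far. Its closest neighbour is compound 2 `O=C(N[C@H]1CCC[C@H](CO)C1)C1CCN(c2nc3cc(Cl)c(-c4cccc(Cl)c4)cc3o2)CC1`, which in this assay gives 55.8 mL/min/kg; the step of a 1.5-fold lower number from compound 1 to compound 2 (0.17 log units; within the scatter) lies within the scatter. Further off stands compound 3 `O=C(N[C@H]1CCC[C@H](CO)C1)C1CCN(c2nc3cc(C(F)(F)F)ccc3o2)CC1`, which in this assay gives 22.2 mL/min/kg, a number beyond the scatter from that of compound 1; compound 3 differs from compound 1 in more than one place, so no single step can be drawn between them.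

Compound 4 `CCc1cc2oc(N3CCC(C(=O)N[C@H]4CCC[C@H](CO)C4)CC3)nc2cc1Cl` has not yet been measured in this assay. Compared with compound 1 the change is ethyl in place of 4-fluorophenyl on an aromatic carbon. Among the measured compounds shown here, no measured step mirrors this change: the one step known, a 1.5-fold lower number from compound 1 to compound 2 (0.17 log units; within the scatter), swaps one aryl group for another and stays within the scatter. For the measured compounds named here, the only hint is that compound 3, which also carries no pendant aryl, gives 22.2 mL/min/kg. The step of a 1.8-fold lower number from compound 1 to compound 4 (0.26 log units; within the scatter) is therefore expected to run toward a lower number, with little confidence. Compound 4 is estimated at 45 mL/min/kg in this assay, within 20 mL/min/kg to 95 mL/min/kg.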

Compound 4, clearance: 64.6 mL/min/kg
Compound 4: the middle estimate sits 1.4-fold (0.16 log units) below what was measured; the measured number falls inside the stated range.
By their numbers in this assay, from the lowest: compound 3; then compounds 2, 4 and 1 (each within the scatter of the next).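

In this assay ethyl in place of 4-fluorophenyl gives a 1.3-fold lower number from compound 1 to compound 4 (0.10 log units; within the scatter) and ethyl in place of 3-chlorophenyl gives a 1.2-fold higher number from compound 2 to compound 4 (0.06 log units; within the scatter) at the same aromatic carbon, ortho to a chloro group. The earlier step only swapped one aryl group for another, whereas these two show that replacing the whole six-membered aromatic ring with a two-carbon ethyl group also leaves the clearance within the scatter of both aryl compounds. Nothing available explains this result.

The compounds shown leave open whether an amine, a carboxylic acid or a longer chain at this carbon would move the number beyond the scatter. Among these compounds, they also leave open what the ethyl group does with the chloro group replaced by hydrogen, since no step isolates that group.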